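Swapping chloro for methoxy on the most potent compound

A few compounds are considered here, and "the series" means these few. Any claim that something is new, unique, unknown or untested is made for them only; others in the source may bear on it.

Compound 1 `Nc1nc(N2CCN(C(=O)COc3ccc(Cl)cc3)CC2)c2nc(Cc3ccc(F)cc3)sc2n1` gives 700 nM in a functional assay on cells (Lymphocyte, Homo sapiens); on this read-out lower numbers stand for stronger inhibition and higher numbers for weaker inhibition.
Compound 2 `Nc1nc(N2CCN(C(=O)COc3ccc(Cl)cc3)CC2)c2nc(CCc3ccc(F)cc3)sc2n1` gives 4400 nM in this assay.
Compound 3 `Nc1nc(N2CCN(C(=O)COc3ccc(Cl)cc3)CC2)c2nc(-c3cccnc3)sc2n1` gives 50 nM in this assay.

Compound 3 has the lowest number of the three: a 14-fold lower number from compound 1 to compound 3 (1.15 log units; beyond the scatter) and an 88-fold lower number from compound 2 to compound 3 (1.94 log units; beyond the scatter), while a 6.3-fold higher number from compound 1 to compound 2 (0.80 log units; beyond the scatter). Compound 4 `COc1ccc(OCC(=O)N2CCN(c3nc(N)nc4sc(-c5cccnc5)nc34)CC2)cc1` keeps the group that sets compound 3 apart and changes only the far end: methoxy in place of chloro on an aromatic carbon. None of the three measured steps touches this part of the molecule; all of them alter the group on the shared core. Within the data shown here, no measured step therefore bears on the change, and no step beyond the scatter is expected, a 1.1-fold higher number from compound 3 to compound 4 (0.04 log units; within the scatter). Compound 4 is estimated at 55 nM, with a range from 15 nM to 200 nM.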

Compound 4, half-maximal inhibitory concentration: 12 nM
Compound 4: middle estimate off by 4.6-fold (0.66 log units), on the high side, outside the stated range (below it).
By their numbers in this assay, from the lowest: compound 4; then compound 3; then compound 1; then compound 2.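

The far end of the molecule matters too: with pyridin-3-yl held fixed, methoxy in place of chloro gives a 4.2-fold lower number from compound 3 to compound 4 (0.62 log units; beyond the scatter), whereas every earlier step changed only the group on the shared core. Nothing available accounts for this gain.

From the compounds shown here alone, it remains open whether the gain is specific to methoxy, which an ethoxy, hydroxy or dimethylamino group at the same place would test. Also open, going by these compounds, is whether the same swap would lower the number with the 4-fluorobenzyl group of compound 1 on the core.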